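Swapping an Azetidine for a Piperidine on the Shared Core

The compounds below may be only part of what the source reports. "The series", "measured", "known", "first", "only" and "open" are said of these compounds alone.

Compound 3 `FC(F)(F)c1cc(NCC2CNC2)c2cn[nH]c2c1` gives 10% in an assay for inhibition of Indoleamine 2,3-dioxygenase 1 (Homo sapiens), with stated times of 10 min and 60 min, tested at 10 uM (on this read-out higher numbers stand for a stronger effect at the one concentration tested and lower numbers for a weaker effect), the lowest of the three numbers gathered so far. Compound 1 `Oc1ccc(CNc2cc(C(F)(F)F)cc3[nH]ncc23)cc1` gives 37% in this assay, and compound 2 `COc1cc(CNc2cc(Br)cc3[nH]ncc23)c([N+](=O)[O-])cc1OC` gives 48% in this assay. Among the measured compounds shown here, the only measured step that reaches compound 3 is a number 27 percentage points lower from compound 1 to compound 3 (beyond the scatter), a modest fall that lies beyond the scatter.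

Compound 4 `FC(F)(F)c1cc(NC[C@H]2CCCCN2)c2cn[nH]c2c1` differs from compound 3 in one place: piperidin-2-yl in place of azetidin-3-yl on a saturated chain carbon bound to a nitrogen on an aromatic ring. For the measured compounds named here, no measured pair exchanges one saturated ring for another on that chain carbon; the single step that touches this position concerns an aromatic group leaving and an azetidine arriving, not a change from a four-membered to a six-membered saturated ring. Going by the values given here, that step therefore offers no direct guide, and nothing among the measured compounds points to a move in either direction that would clear the scatter. The expectation is for compound 4 to sit close to compound 3, with the estimated step of a number 5 percentage points higher from compound 3 to compound 4 (within the scatter) staying within the scatter. Compound 4 is accordingly expected to give about 15%, with a range from 0% to 35%.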

Compound 4, a percentage reported as inhibition, at one concentration (the size of the read-out at that concentration, not a potency): 19%
For compound 4 the middle estimate is 4 percentage points below the measured one; low and high end bracket the measured number.
By their numbers in this assay, from the lowest: compounds 3 and 4 (each within the scatter of the next); then compound 1; then compound 2.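

Putting piperidin-2-yl in place of azetidin-3-yl on the saturated chain carbon gives a number 9 percentage points higher from compound 3 to compound 4 (within the scatter), so this assay does not separate these two saturated rings, even though piperidin-2-yl has the larger ring and a defined stereocentre. The second step, a number 18 percentage points lower from compound 1 to compound 4 (beyond the scatter), shows that the fall first seen with azetidin-3-yl in place of 4-hydroxyphenyl also appears with a second saturated ring containing one nitrogen, so on this core it is not confined to the four-membered ring. Nothing available explains either step.

The compounds shown leave open whether the mirror-image form of piperidin-2-yl or a pyrrolidine ring on the same chain carbon would also stay within the scatter of compound 3. They also leave open whether the fall from compound 1 follows the arrival of the ring nitrogen or the loss of the aromatic ring, a question that cyclohexyl or unsubstituted phenyl at this place would help to separate.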